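This account rests on a few compounds, and the source may have more. Where it says the series, first, only, none or still open, it means among the compounds named here.

Measured in a functional assay on U-373MG ATCC cells for inhibition, with U373 MG (Homo sapiens) as the target, read by MTT assay, with a stated time of 7 days (a lower number here means a stronger inhibitor of growth, a higher number a weaker inhibitor of growth), the compounds so far are:

Compound 1 `C[Si](C)(C)CCOCn1nnc2c(C(N)=O)ncn2c1=O` gives 25300 nM
Compound 2 `NC(=O)c1ncn2c(=O)n(Cc3ccccc3)nnc12` gives > 50000 nM (a limit of the assay)
Compound 3 `COc1ccc(Cn2nnc3c(C(N)=O)ncn3c2=O)cc1` gives > 50000 nM (a limit of the assay)

Compound 3 therefore has no number, and its place is the limit of > 50000 nM in this assay, at which 2 of the 3 values shown sit. Compound 4 `COc1ccc(Cn2nnc3c(C(N)=O)ncn3c2=O)c(OC)c1` differs from compound 3 by a single change, (methoxy in place of hydrogen on an aromatic carbon), which is methoxy in place of hydrogen on an aromatic carbon. The closest measured precedent is the same kind of change, a step that the two limits leave unreadable from compound 2 to compound 3, so it gives no size to carry over. The other step, an at least 1.9-fold higher number from compound 1 to compound 2 (0.29 log units; that floor lies within the scatter), replaces a different group and bears on this change only weakly. With nothing readable pointing either way, no step beyond the scatter is expected in this assay, and compound 4 is expected to stay near the limit shared by compound 2 and compound 3. The expected step is a step that the limit leaves unreadable from compound 3 to compound 4. For compound 4 the estimated value is 60000 nM, with an expected range from 25000 nM to 120000 nM.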

Compound 4, concentration for 50% growth inhibition: > 50000 nM
Compound 4: a limit, no number; the forecaster's own chance of this, stated with the estimate: 85%; the middle value is on the limit's open side.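

In this assay compound 4 gives > 50000 nM, a limit and not a number. Among the compounds shown here, compound 3 also stands at a limit, so no step from compound 3 to compound 4 can be read. The compounds shown leave open whether methoxy in place of hydrogen on an aromatic carbon changes growth inhibition at all, since most values stop at one mark: the limit of > 50000 nM in this assay, at which 3 of the 4 values shown sit.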